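Removing a Ring Fluorine from Amidine-Bearing Biaryl Thiophenes

The source may hold more compounds than are shown below. What is called first, only, known or untested is meant among the compounds shown, and "the series" means these compounds.

Measured so far:
Compound 1, `COc1cc(OC)cc(-c2ccc(-c3ccc(C(=N)N)c(F)c3)s2)c1`: 712 nM
Compound 2, `N=C(N)c1ccc(-c2ccc(-c3ccc(Cl)cc3)s2)cc1F`: 517 nM
Compound 3, `N=C(N)c1ccc(-c2ccc(-c3ccc(Cl)cc3)s2)cc1`: 180 nM

Of the compounds shown here, three have been tested in a functional assay on SN12C cells (Homo sapiens) for inhibition, read by sulforhodamine B assay, with a stated time of 48 h; on this read-out higher numbers stand for weaker inhibition of growth and lower numbers for stronger inhibition of growth. Compound 2 and compound 3 differ in one place, (hydrogen in place of fluoro on an aromatic carbon), and this change gave a 2.9-fold lower number from compound 2 to compound 3 (0.46 log units; beyond the scatter). Compound 1 returned the highest number of the three, but its value and that of compound 2 lie within the usual scatter of each other, so no order between them can be claimed; compound 3, by contrast, sits clearly lower than compound 1. The difference between the cores of compound 1 and compound 2 is not broken down here.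

Compound 4, `COc1cc(OC)cc(-c2ccc(-c3ccc(C(=N)N)cc3)s2)c1`, has not yet been measured. Among the measured compounds shown here, it differs from compound 1 by hydrogen in place of fluoro on an aromatic carbon, which is the same change as the one from compound 2 to compound 3, at the same kind of place. Because the earlier step was a 2.9-fold lower number from compound 2 to compound 3 (0.46 log units; beyond the scatter), compound 4 is expected to move by a 2.8-fold lower number from compound 1 to compound 4 (0.45 log units; beyond the scatter) in this assay. Compound 4 is therefore estimated at 250 nM, most likely between 100 nM and 600 nM.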

Compound 4, concentration for 50% growth inhibition: 1970 nM
Beside the measured number, compound 4's estimate is 7.9-fold (0.90 log units) below it; measured number above the stated range.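

In this assay, putting hydrogen in place of fluoro on the core of compound 1 gave a 2.8-fold higher number from compound 1 to compound 4 (0.44 log units; beyond the scatter), so the direction seen on the other core did not carry over. Set beside the earlier step, the same change ran opposite ways on the two cores, and the gap between the steps is larger than scatter alone would explain: the same change on two cores in this assay, a 2.9-fold lower number (0.46 log units; beyond the scatter) from compound 2 to compound 3 and a 2.8-fold higher number (0.44 log units; beyond the scatter) from compound 1 to compound 4, 7.9-fold (0.90 log units) apart, beyond the scatter of two such steps This shows that, in these two pairs, the result of removing the fluoro depends on the core that carries it, but it does not show which difference between the cores lies behind the reversal, and two pairs set no rule for the rest of the series.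

The compounds shown leave open how the same change behaves when a nitrile or a methyl stands in place of the chloro or the methoxy groups. They also leave open whether either direction survives when a carboxylic acid or an amine replaces the amidine.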